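A phenyl group gives way to fluoro

The compounds below may be only part of what the source reports. "The series", "measured", "known", "first", "only" and "open" are said of these compounds alone.

Compound 1 (`O=C(Nc1cc(C(F)(F)F)cc(C(F)(F)F)c1)c1cc(Cl)c(F)cc1O`): 730 nM
Compound 2 (`O=C(Nc1cc(C(F)(F)F)cc(C(F)(F)F)c1)c1cc(Br)c(-c2ccccc2)cc1O`): 680 nM

In a functional assay on Jurkat cells (Homo sapiens) for cytotoxicity, read by luminescence and CellTiter-Glo, with a stated time of 3 days (a higher number here means a weaker inhibitor, a lower number a stronger inhibitor), compound 2 gives 680 nM and so lies within the scatter of compound 1 at 730 nM in this small set. Compound 3 (`O=C(Nc1cc(C(F)(F)F)cc(C(F)(F)F)c1)c1cc(Br)c(F)cc1O`) keeps the rest of compound 2 but carries fluoro in place of phenyl on an aromatic carbon, ortho to a bromo group, meta to a hydroxy group and para to a large group (fluoro in place of phenyl on an aromatic carbon). For the measured compounds named here, no step between measured compounds shows what such a change does in this assay so the expectation rests on thin ground. With compound 1 at 730 nM and compound 2 at 680 nM in one narrow band, no shift beyond the scatter is expected, and no direction is favoured. The expected 1.0-fold higher number from compound 2 to compound 3 (0.01 log units; within the scatter) stays within the scatter. The estimated value for compound 3 is 700 nM (expected range 300 nM to 1600 nM).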

Compound 3, half-maximal inhibitory concentration: 700 nM
Estimate against measurement, compound 3: no gap at the digits printed, within the range that was stated.
By their numbers in this assay, from the lowest: compounds 2, 3 and 1 (each within the scatter of the next).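

In this assay, the step of a 1.0-fold higher number from compound 2 to compound 3 (0.01 log units; within the scatter) lies within the scatter, so this aromatic carbon, ortho to a bromo group, meta to a hydroxy group and para to a large group, carries phenyl or fluoro with no readable difference in the number, although a whole ring gives way to a single atom. The second new step, a 1.0-fold lower number from compound 1 to compound 3 (0.02 log units; within the scatter), is also within the scatter: with fluoro kept, bromo in place of chloro on an aromatic carbon leaves the number where it was. Nothing available bears on the reason for this flat result.

On these data alone, whether an amine, a carboxylic acid or a longer chain on the same carbon would move the number stays open. As far as these compounds go, all three compounds carry the hydroxy group and both trifluoromethyl groups unchanged, so what those groups contribute also stays open.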